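Methyl to methoxy on the arylamino substituent

The compounds below may be only part of what the source reports. "The series", "measured", "known", "first", "only" and "open" are said of these compounds alone.

Measured so far:
compound 1 `Cc1ccc(NC2=CC(=O)c3nc4n(c3C2=O)[C@H]2OC[C@@H](O)[C@H]2OC4)cc1` — 1420 nM
compound 2 `O=C1C(N2CCCC2)=CC(=O)c2c1nc1n2[C@H]2OC[C@@H](O)[C@H]2OC1` — > 16000 nM

Among the compounds with values here, compound 1 carries the only number in a functional assay on MGC-803 cells (Homo sapiens) for inhibition, read by sulforhodamine B assay (on this read-out higher numbers stand for weaker inhibition and lower numbers for stronger inhibition), in this series. Within the data shown here, compound 2 reports only a limit here, (the limit of > 16000 nM in this assay, at which 1 of the 2 values shown sits), so no step between the two measured compounds can be sized. Compound 3 `COc1ccc(NC2=CC(=O)c3nc4n(c3C2=O)[C@H]2OC[C@@H](O)[C@H]2OC4)cc1` has not yet been run in this assay. It differs from compound 1 in one place: methoxy in place of methyl on an aromatic carbon. Compounds 1 and 2 differ in more than one place, so they give no guide to the size of such a change. With no measured step of this kind in hand, the step from compound 1 to compound 3 is expected to stay within the usual scatter, in either direction. Compound 3 is estimated at 1400 nM in this assay, with a range from 500 nM to 4000 nM, which means the expected step of a 1.0-fold lower number from compound 1 to compound 3 (0.01 log units; within the scatter).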

Compound 3, half-maximal inhibitory concentration: 1680 nM
Compound 3: the middle estimate sits 1.2-fold (0.08 log units) below what was measured; the measured number falls inside the stated range.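

In this assay, within the data shown here, methoxy in place of methyl on an aromatic carbon, para to a large group, gives a 1.2-fold higher number from compound 1 to compound 3 (0.07 log units; within the scatter), the first step that can be sized. Compound 1 and compound 3 therefore cannot be told apart on this read-out, even though the 4-methoxyphenyl group of compound 3 carries a hydrogen-bond acceptor that the 4-methylphenyl group of compound 1 lacks. Nothing at hand bears on the reason for this result.

Steps to compound 2 cannot be read, as its value is a limit and not a number: the limit of > 16000 nM in this assay, at which 1 of the 3 values shown sits. Open is whether a different group at this same place on the aromatic ring, such as an amine, a carboxylic acid or a longer alkoxy chain, would give a step beyond the scatter from compound 1.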